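Para-methyl removal on the aryl urea of compound 2

The source may report more compounds than this note shows. Statements on the series, on what has been measured and on what is new or still open speak of the compounds shown alone.

Measured compounds:
compound 1, `COc1ccc(CN(C(=O)Nc2ccc(C)cc2)n2cnnc2)cc1OC`, 26300 nM
compound 2, `Cc1ccc(NC(=O)N(Cc2ccccn2)n2cnnc2)cc1`, 21500 nM

Both compounds were tested in a functional assay on DU-145 cells (Homo sapiens) for cytotoxicity, read by MTT assay, with a stated time of 48 h; a lower number here means a stronger inhibitor, a higher number a weaker inhibitor. Compound 1 gives 26300 nM, and compound 2 gives 21500 nM; the gap between the two lies within the scatter, so neither can be set apart from the other on these numbers alone, and both are weak.

Compound 3, `O=C(Nc1ccccc1)N(Cc1ccccn1)n1cnnc1`, has not yet been measured in this assay. It differs from compound 2 by hydrogen in place of methyl on an aromatic carbon. Among the measured compounds shown here, with only two measured compounds and no step between them that isolates this change, there is nothing to suggest a large move in either direction; a step from compound 2 to compound 3 no bigger than the scatter is expected, a 1.2-fold higher number from compound 2 to compound 3 (0.07 log units; within the scatter). Compound 3 is therefore estimated at 25000 nM, with a range from 10000 nM to 65000 nM.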

Compound 3, half-maximal inhibitory concentration: 20200 nM
Beside the measured number, compound 3's estimate is 1.2-fold (0.09 log units) above it, and the stated range covers the measured number.
By their numbers in this assay, from the lowest: compounds 3, 2 and 1 (each within the scatter of the next).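

In this assay, among the compounds shown here, replacing methyl with hydrogen on the aromatic carbon para to a large group gives a 1.1-fold lower number from compound 2 to compound 3 (0.03 log units; within the scatter) and is the first change here that can be read in one place alone. The exchange of 4-methylphenyl for phenyl therefore leaves no difference that this assay can resolve. At this position, the methyl is not required for the weak activity seen with compound 2, although a single step cannot show how the position behaves more generally.

Going by these compounds, whether an amine, a methoxy group, a chlorine atom or a carboxylic acid at the same place would give a step beyond the scatter remains open, as does whether the same exchange would read alike on the core of compound 1. No measured evidence bears on this result.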